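Swapping a Benzyloxy Arm for a Spirocyclic Amine

The source may hold more compounds than are shown below. What is called first, only, known or untested is meant among the compounds shown, and "the series" means these compounds.

Measured compounds:
- Compound 1 `COc1cccc(CN2C(=O)CN(C(=O)c3cc4cc(OC)ccc4[nH]3)C[C@@H]2COCc2ccccc2)c1`: 11700 nM
- Compound 2 `COc1ccc2[nH]c(C(=O)N3CC(=O)N(Cc4ccccc4)[C@@H](COCc4ccccc4)C3)cc2c1`: 8800 nM
- Compound 3 `COc1ccc2[nH]c(C(=O)N3CC(=O)N(Cc4ccoc4)[C@@H](Cc4ccccc4)C3)cc2c1`: 63600 nM

Of the compounds shown here, three sharing one core have been tested in a physicochemical assay for solubility, read by spectrophotometry, in phosphate buffer, with a stated time of 2 h, at pH 7.4; on this read-out lower numbers stand for lower solubility and higher numbers for higher solubility. Compound 2 stands at the low end of the three numbers: the step of a 1.3-fold lower number from compound 1 to compound 2 (0.12 log units; within the scatter) is within the scatter, so compound 1 and compound 2 are not distinguishable, while compound 3, which differs from compound 2 in more than one place, gives a clearly higher number.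

Compound 4 `COc1ccc2[nH]c(C(=O)N3CC(=O)N(Cc4ccccc4)[C@@H](CN4CC5(CCC5)C4)C3)cc2c1` is not yet measured. It differs from compound 2 as follows: a group of 7 heavy atoms (6 carbon, 1 nitrogen; one four-membered non-aromatic ring of carbon only, one four-membered non-aromatic ring with 1 hetero atom) in place of a group of 8 heavy atoms (7 carbon, 1 oxygen; one six-membered aromatic ring of carbon only), on a saturated chain carbon bound to a saturated ring carbon

For the measured compounds named here, no measured step touches this position; the only step on record concerns a methoxy on the aromatic core and was within the scatter. The expectation for compound 4 therefore rests on compound 2 alone, with wide uncertainty. Compound 4 is expected to give about 25000 nM, with a range from 7000 nM to 90000 nM. This estimate means a step of a 2.8-fold higher number from compound 2 to compound 4 (0.45 log units; beyond the scatter), an expected rise that could equally fall within the scatter.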

Compound 4, solubility: 60700 nM
Compound 4: middle estimate off by 2.4-fold (0.39 log units), on the low side; measured number inside the range.
By their numbers in this assay, from the lowest: compounds 2 and 1 (each within the scatter of the next); then compounds 4 and 3 (each within the scatter of the next).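

For the compounds shown here, this is the first step on record at the saturated chain carbon bound to a saturated ring carbon, and in this assay replacing benzyloxy with the spirocyclic amine gives a 6.9-fold higher number from compound 2 to compound 4 (0.84 log units; beyond the scatter), so a change at this position can move the number beyond the scatter. The computed counts of hydrogen-bond donors and acceptors and the net charge are the same for both groups, while the six-membered aromatic ring of carbon only gives way to two four-membered non-aromatic rings, one of them holding a nitrogen. No evidence at hand links the higher number to any particular feature of this swap.

From the compounds shown here alone, it remains open whether the aromatic ring leaving or the amine nitrogen entering matters more. A cyclohexyloxy group at this position would keep the oxygen without the aromatic ring, and a benzylamine would keep the aromatic ring with a nitrogen in place of that oxygen.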